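Furan-2-yl for Methyl on an Oxadiazole: Cytotoxicity Outlook

This account rests on a few compounds, and the source may have more. Where it says the series, first, only, none or still open, it means among the compounds named here.

Compound 1 `COc1nc2ccccc2cc1/C=C/c1noc(-c2ccccc2)n1`: a limit, > 240000 nM
Compound 2 `COc1nc2ccccc2cc1/C=C/c1noc(-c2ccc(Br)cc2)n1`: a limit, > 195000 nM
Compound 3 `COc1nc2ccccc2cc1/C=C/c1noc(C)n1`: a limit, > 300000 nM

Among the measured compounds shown here, in an ADME assay on HepG2 cells (Homo sapiens) for cytotoxicity, read by sulforhodamine B assay, with a stated time of 48 h (a lower number here means that less compound is tolerated, a higher number that more compound is tolerated), every value so far is a limit of the assay rather than a number. Compound 3 sits at the limit of > 300000 nM in this assay, at which 1 of the 3 values shown sits, and the two other compounds sit at the limit of > 195000 nM in this assay, at which 1 of the 3 values shown sits, and (the limit of > 240000 nM in this assay, at which 1 of the 3 values shown sits), so compound 3 stands level with the rest as far as the limits allow one to say.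

Compound 4 `COc1nc2ccccc2cc1/C=C/c1noc(-c2ccco2)n1` carries furan-2-yl in place of methyl on an aromatic carbon. The measured steps that bear on a change at this position are a step that the two limits leave unreadable from compound 1 to compound 3, a step that the two limits leave unreadable from compound 2 to compound 3 and a step that the two limits leave unreadable from compound 1 to compound 2; none of them can be read, since both ends of each are limits. Swapping phenyl, 4-bromophenyl and methyl at this carbon has therefore left no readable mark in this assay, and the furan-2-yl group is of a similar kind. No step beyond the scatter is expected from compound 3 to compound 4 in this assay.

Compound 4 is accordingly estimated at 300000 nM, within 100000 nM to 1000000 nM, with the step of a number no higher from compound 3 to compound 4 (the limit leaves the size open) expected to be flat, and most likely the assay will again report only a limit.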

Compound 4, half-maximal cytotoxic concentration: > 250000 nM
Compound 4 ended at the assay's limit (the forecaster's own chance of this, stated with the estimate: 85%); the middle value does not contradict the limit.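

Compound 4, like compound 1, compound 2 and compound 3, gives only a limit in this assay, so none of the steps from those three compounds to compound 4 can be read. The compounds shown leave open where the half-maximal cytotoxic concentration of each actually lies, and whether the group on this aromatic carbon affects it at all.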